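The compounds below may be only part of what the source reports. "The series", "measured", "known", "first", "only" and "open" are said of these compounds alone.

Compound 1 `C=C1C(=O)[C@]23C[C@@]1(O)CC[C@H]2c1ccc(OS(=O)(=O)c2ccc(C)cc2)c(C)c1[C@@H]3Cn1cc(-c2ccccn2)nn1` and compound 2 `C=C1C(=O)[C@]23C[C@@]1(O)CC[C@H]2c1ccc(OS(=O)(=O)c2ccc(C)cc2)c(C)c1[C@@H]3Cn1cc(-c2ccc(F)cc2)nn1` share one core, while compound 3 `C=C1C[C@]23C[C@@]1(O)CC[C@H]2c1cc(Br)c(O)c(C)c1[C@@H]3Cn1cc(-c2ccc(F)cc2)nn1` rests on a different core; the difference between the two cores is not broken down here. In a functional assay on MCF7 cells (Homo sapiens) for cytotoxicity, read by MTT assay, with a stated time of 4 days (on this read-out lower numbers stand for stronger inhibition and higher numbers for weaker inhibition), compound 1 gives 320 nM and compound 2 gives 330 nM, so the change pyridin-2-yl in place of 4-fluorophenyl on an aromatic carbon made a step of a 1.0-fold lower number from compound 2 to compound 1 (0.01 log units; within the scatter). Compound 3 gives 19200 nM in this assay, far from both. Compound 4 `C=C1C[C@]23C[C@@]1(O)CC[C@H]2c1cc(Br)c(O)c(C)c1[C@@H]3Cn1cc(-c2ccccn2)nn1` is reached from compound 3 by the same change, (pyridin-2-yl in place of 4-fluorophenyl on an aromatic carbon). Among the compounds with values here, since the only measured example of this change, the step of a 1.0-fold lower number from compound 2 to compound 1 (0.01 log units; within the scatter), stayed within the scatter, compound 4 is expected to stay close to compound 3, with an estimated step of a 1.0-fold lower number from compound 3 to compound 4 (0.00 log units; within the scatter). In this assay compound 4 is thus estimated at 19000 nM, expected between 8000 nM and 45000 nM.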

Compound 4, half-maximal inhibitory concentration: > 20000 nM
Compound 4: a limit, no number (the forecaster's own chance of this, stated with the estimate: 15%); at least 1.0-fold (0.02 log units) between middle value and limit.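

In this assay compound 4 gives > 20000 nM and this is a limit of the assay, not a number. The step on this core can therefore be read only as a floor, an at least 1.0-fold higher number from compound 3 to compound 4 (0.01 log units; that floor lies within the scatter) and the two cores compare as follows: the same change on two cores in this assay, a 1.0-fold lower number (0.01 log units; within the scatter) from compound 2 to compound 1 and an at least 1.0-fold higher number (0.01 log units; that floor lies within the scatter) from compound 3 to compound 4; the limit leaves it open whether they differ. On these data alone, the pair thus gives no sign that pyridin-2-yl in place of 4-fluorophenyl acts differently on the second core, but it does not show that the change carries over unaltered either, and its true size there remains unknown.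

Only pyridin-2-yl and 4-fluorophenyl stand at this place on the triazole-free wording of the data, a five-membered aromatic ring with 3 nitrogen. As far as these compounds go, how an amine or a carboxylic acid there would read on either core stays open.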